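Notes on the group at the aromatic nitrogen

The source may report more compounds than this note shows. Statements on the series, on what has been measured and on what is new or still open speak of the compounds shown alone.

Of the compounds shown here, three have been measured: compound 1 `Cn1c(=O)c(S(=O)(=O)Cc2ccc(F)cc2)cc2cnc(Nc3ccc4[nH]ccc4c3)nc21`, compound 2 `O=c1c(S(=O)(=O)c2ccc(F)cc2F)cc2cnc(Nc3ccc4[nH]ccc4c3)nc2n1CC1CC1` and compound 3 `COc1ccc(S(=O)(=O)c2cc3cnc(Nc4ccc5[nH]ccc5c4)nc3n(C)c2=O)cc1`. Compound 4 `O=c1c(S(=O)(=O)c2ccc(F)cc2F)cc2cnc(Nc3ccc4[nH]ccc4c3)nc2n1C1CCCCC1` has not. In a functional assay on K562 cells (Homo sapiens) for inhibition, read by trypan blue exclusion, with a stated time of 72 h (a lower number here means a stronger inhibitor, a higher number a weaker inhibitor), compound 1 gives 30000 nM, compound 3 gives 300 nM and compound 2 gives 1000 nM. Compound 2 thus stands second highest of the three numbers; compound 3 lies closest to it and compound 1 furthest from it, both gaps beyond the scatter.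

The change from compound 2 to compound 4 is cyclohexyl in place of cyclopropylmethyl on an aromatic nitrogen. Among the measured compounds shown here, the single measured step, a 100-fold lower number from compound 1 to compound 3 (2.00 log units; beyond the scatter), concerns the group on the sulfonyl sulfur, not the group on the aromatic nitrogen, so it does not bear on this change. For the measured compounds named here, no measured pair varies the group on the aromatic nitrogen, and nothing here sets a direction. The expectation is therefore a step of no more than the scatter, no change at the digits printed from compound 2 to compound 4 (within the scatter). Compound 4 is estimated at 1000 nM in this assay, with a range from 300 nM to 3000 nM.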

Compound 4, half-maximal inhibitory concentration: 10000 nM
Compound 4: the middle estimate sits 10-fold (1.00 log units) below what was measured; measured number above the stated range.
By their numbers in this assay, from the lowest: compound 3; then compound 2; then compound 4; then compound 1.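

Among the compounds shown here, the group on the aromatic nitrogen is not a silent position in this assay: with the (2,4-difluorophenyl)sulfonyl group held fixed, cyclohexyl in place of cyclopropylmethyl, the first measured change at this position, gives a 10-fold higher number from compound 2 to compound 4 (1.00 log units; beyond the scatter). Neither group carries a hydrogen-bond donor, a hydrogen-bond acceptor or a net charge, so this weakening appears with no difference in those counts, only with a six-membered carbon ring in place of a three-membered one and more carbon. No supporting measurement is available to explain the step.

On these data alone, two groups do not define a trend at this position, so it remains open how a longer chain, a hydroxyethyl group or a chain ending in an amine would compare. Also open, as far as these compounds go, is whether the same step holds with 4-methoxyphenyl on the sulfonyl sulfur.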